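The source may report more compounds than this note shows. Statements on the series, on what has been measured and on what is new or still open speak of the compounds shown alone.

Measured so far:
Compound 1 `ClCc1ccc(Cn2cnc3c(Cl)ncnc32)cc1` — in a functional assay on Hs-578T cells (Homo sapiens) for cytotoxicity, read by sulforhodamine B assay, with a stated time of 48 h (on this read-out higher numbers stand for lower toxicity in this test and lower numbers for higher toxicity in this test), compound 1 gives > 100000 nM, a limit of the assay.
Compound 2 `ClCc1ccccc1Cn1cnc2c(Cl)nc(Cl)nc21` — in this assay compound 2 gives > 100000 nM, likewise a limit of the assay.

Compound 2 stands at the limit of > 100000 nM in this assay, at which 2 of the 2 values shown sit, so no number is known for it, only that its read-out lies at the top end of what the test reports. Among the measured compounds shown here, no step between measured compounds exists in this set. Compound 3 `ClCc1ccccc1Cn1cnc2c(Cl)ncnc21` differs from compound 2 by hydrogen in place of chloro on an aromatic carbon. With both measured values sitting as limits, no direction can be read from the numbers shown, and the change removes a single chlorine. The step from compound 2 to compound 3 in this assay is expected to be small, with no shift beyond the scatter, and the likeliest outcome is a further limit. Compound 3 is therefore estimated at 150000 nM, range 80000 nM to 400000 nM. The expected step is a step that the limit leaves unreadable from compound 2 to compound 3.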

Compound 3, concentration lethal to 50% of the cells: 56200 nM
The estimate for compound 3 lay 2.7-fold (0.43 log units) above the measured number; the measured number lies below the stated range.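

In this assay, among the compounds shown here, hydrogen in place of chloro on the aromatic carbon between two ring nitrogen atoms gives an at least 1.7-fold lower number from compound 2 to compound 3 (0.25 log units; that floor lies within the scatter) and compound 3 is the first of the set to return a number rather than a limit. Compound 1 also carries hydrogen at this position and gives > 100000 nM as a limit of the assay, so hydrogen here does not by itself bring a number. The true size of the step cannot be read because compound 2 sits at a limit: the limit of > 100000 nM in this assay, at which 2 of the 3 values shown sit.

On these data alone, whether this change carries any real shift stays open, since the floor of the step does not clear the scatter. The read-out with an amine or a methoxy group on this carbon also remains unknown from the compounds shown.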